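The source may hold more compounds than are shown below. What is called first, only, known or untested is meant among the compounds shown, and "the series" means these compounds.

For the measured compounds named here, compound 2, `CC1=C(C(=O)OC(C)C)C(c2cccs2)N/C(=N/C#N)N1`, stands highest of the two compounds measured so far. In an assay on HeLa cells for displacement of a labelled ligand from adenosine receptor A3 (Homo sapiens), with a stated time of 180 min, tested at 1 uM (on this read-out lower numbers stand for less inhibition and higher numbers for more inhibition at the one concentration tested (going by the name of the read-out)), compound 2 gives 27%, whereas compound 1, `CC1=C(C(=O)OC(C)C)C(C2CCCC2)N/C(=N/C#N)N1`, gives 3%. Going by the values given here, the single measured step, a number 24 percentage points higher from compound 1 to compound 2 (beyond the scatter), is the only change recorded on this saturated ring carbon, and it brought thiophen-2-yl in place of cyclopentyl. Compound 3, `CC1=C(C(=O)OC(C)C)C(c2ccoc2)N/C(=N/C#N)N1`, has not yet been measured in this assay. It differs from compound 2 in one place: furan-3-yl in place of thiophen-2-yl on a saturated ring carbon. Among the compounds with values here, no measured step exchanges one five-membered aromatic ring for another, so the only guide is that compound 2, carrying thiophen-2-yl, gives 27%, while compound 1, carrying cyclopentyl, gives 3%. The expected step of a number 7 percentage points lower from compound 2 to compound 3 (within the scatter) is therefore small and is not expected to go beyond the scatter. Compound 3 is estimated at 20%, with a range from 5% to 40%.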

Compound 3, a percentage reported as inhibition, at one concentration (the size of the read-out at that concentration, not a potency): 41%
Compound 3: middle estimate off by 21 percentage points, on the low side; the whole stated range lies below it.
By their numbers in this assay, from the lowest: compound 1; then compound 2; then compound 3.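

Replacing one five-membered aromatic ring with another at this saturated ring carbon is not a neutral exchange: in this assay, the change gives a number 14 percentage points higher from compound 2 to compound 3 (beyond the scatter), even though the two groups match on every count computed from their structures. Measured against the saturated cyclopentyl group, furan-3-yl gives a number 38 percentage points higher from compound 1 to compound 3 (beyond the scatter), the largest step seen so far at this carbon. No measured evidence is available to explain why these groups differ.

The change from thiophen-2-yl to furan-3-yl alters both the hetero atom, sulfur to oxygen, and the point at which the ring is attached, so the result cannot say which alteration matters. A furan-2-yl or thiophen-3-yl group would separate the two, while a phenyl ring would show how a six-membered aromatic ring compares at this carbon.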